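The compounds below may be only part of what the source reports. "The series", "measured", "known", "first", "only" and "open" are said of these compounds alone.

Measured so far in an ADME assay on PC-3 cells (Homo sapiens) for cytotoxicity, read by WST assay, tested at 100 uM; on this read-out higher numbers stand for more inhibition at the one concentration tested (going by the name of the read-out) and lower numbers for less inhibition:

- compound 1 `Cc1cccc(C(=O)N2CCCC(C(=O)Nc3ccc(Cl)cc3)C2)c1` gives 0%
- compound 2 `O=C(Nc1cccc(Oc2ccccn2)c1)C1CCCN(C(=O)c2cc(C(F)(F)F)cc(C(F)(F)F)c2)C1` gives 0%
- compound 3 `O=C(Nc1cccc(Oc2ccccc2)c1)C1CCCN(C(=O)c2cccc(-c3ccco3)c2)C1` gives 0%

Compound 2 stands level with compounds 1 and 3 at the digits shown. Its nearest neighbour on the numbers is compound 1, with no change at the digits shown, within the scatter; its furthest is compound 3, again with no change at the digits shown, within the scatter. None of the three shows any inhibition of cell viability at the single concentration tested.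

Compound 4 `CSc1cccc(NC(=O)C2CCCN(C(=O)c3cc(C(F)(F)F)cc(C(F)(F)F)c3)C2)c1` is the next compound for this assay and has not been measured. Relative to compound 2 the change is methylsulfanyl in place of (pyridin-2-yl)oxy on an aromatic carbon

Going by the values given here, no step between measured compounds is available to size this change. The three measured compounds all sit at the floor of the read-out, so no step beyond the scatter is expected from compound 2 to compound 4, in either direction. Compound 4 is therefore estimated at 0%, in the range -8% to 12%, which means an expected step of no change at the digits printed from compound 2 to compound 4 (within the scatter).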

Compound 4, a percentage reported as inhibition, at one concentration (the size of the read-out at that concentration, not a potency): 0%
Compound 4: the middle estimate sits on the measured number at the digits printed; low and high end bracket the measured number.
By their numbers in this assay, from the lowest: compounds 1, 2, 3 and 4 (each within the scatter of the next).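

In this assay, going by these compounds alone, methylsulfanyl in place of (pyridin-2-yl)oxy on an aromatic carbon, meta to a large group, shows no change at the digits printed from compound 2 to compound 4 (within the scatter) and gives the first readable step at this position. The six-membered aromatic ring with its hetero atom can therefore go, taking the group from 7 heavy atoms to 2, without the read-out leaving its floor. No measurement shown explains this result.

With both compounds at the floor, the step cannot show whether either group has any effect of its own on the read-out. On these data alone, what an amine or a carboxylic acid on this aromatic carbon would give stays open, as does whether any group here lifts the read-out above the floor.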